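Thiophen-2-yl for iodo at a nucleoside core

This account rests on a few compounds, and the source may have more. Where it says the series, first, only, none or still open, it means among the compounds named here.

The account follows the step from compound 1 to compound 3 in a functional assay on K562 cells (Homo sapiens), read by MTT assay, with a stated time of 72 h; a lower number here means a stronger inhibitor, a higher number a weaker inhibitor. Compound 1 has the structure `Cc1ncnc2c1c(I)cn2[C@@H]1O[C@H](CO)[C@@H](O)[C@H]1O`. In this assay compound 1 gives > 20000 nM, which is a limit of the assay and not a measured number. Compound 2, with the structure `COc1nc(N)nc2c1c(-c1ccsc1)cn2[C@@H]1O[C@H](CO)[C@@H](O)[C@H]1O`, is the other measured compound. In this assay compound 2 gives > 20000 nM, again a limit rather than a number. Within the data shown here, compound 1 therefore stands at the limit of > 20000 nM in this assay, at which 2 of the 2 values shown sit, so nothing in the numbers separates the two measured compounds, and no step between them is counted.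

Compound 3 has the structure `Cc1ncnc2c1c(-c1cccs1)cn2[C@@H]1O[C@H](CO)[C@@H](O)[C@H]1O` and has not yet been measured. It differs from compound 1 by thiophen-2-yl in place of iodo on an aromatic carbon. Among the measured compounds shown here, no measured step shows what this change does here, and compound 2, which also carries a thiophene ring, gives only a limit. The step from compound 1 to compound 3 is expected to stay within the scatter, as a step that the limit leaves unreadable from compound 1 to compound 3. Compound 3 is therefore estimated at 25000 nM, with a range from 8000 nM to 80000 nM, and most likely the assay will again report only a limit.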

Compound 3, half-maximal inhibitory concentration: > 20000 nM
Compound 3 was reported as a limit; the forecaster's own chance of this, stated with the estimate: 75%; the middle value is on the limit's open side.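

In this assay compound 3 gives > 20000 nM, a limit of the assay and not a number. Compound 1 and compound 3 therefore yield no readable step, and all compounds shown rest on the same limit: the limit of > 20000 nM in this assay, at which 3 of the 3 values shown sit.

The compounds shown leave open how thiophen-2-yl compares with iodo on this aromatic carbon, and whether any compound here has a measurable value.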